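Sulfamoyl for methyl on the aryl of compound 1

The source may hold more compounds than are shown below. What is called first, only, known or untested is meant among the compounds shown, and "the series" means these compounds.

Compound 1 `Cc1cccc(-n2nncc2CN2C(=O)C3(C(C#N)=C(N)Oc4c3c3nc5ccccc5nc3c3ccccc43)c3ccccc32)c1` is the reference point. In a functional assay on HCT-116 cells (Homo sapiens) for antiproliferative activity, read by MTT assay, with a stated time of 48 h (a higher number here means a weaker inhibitor, a lower number a stronger inhibitor), compound 1 gives only a limit, > 50000 nM. Compound 2 `N#CC1=C(N)Oc2c(c3nc4ccccc4nc3c3ccccc23)C12C(=O)N(Cc1cnnn1-c1cccc(Cl)c1)c1ccccc12` is reported in this assay likewise only as a limit, > 50000 nM. Compound 3 `COc1ccccc1-n1nncc1CN1C(=O)C2(C(C#N)=C(N)Oc3c2c2nc4ccccc4nc2c2ccccc32)c2ccccc21` reaches in this assay again only a limit, > 50000 nM. The steps a step that the two limits leave unreadable from compound 1 to compound 2 and a step that the two limits leave unreadable from compound 1 to compound 3 start from compound 1 but carry no readable size, as a step that the two limits leave unreadable from compound 2 to compound 3 does not either, because of the limit of > 50000 nM in this assay, at which 3 of the 3 values shown sit. Compound 4 `N#CC1=C(N)Oc2c(c3nc4ccccc4nc3c3ccccc23)C12C(=O)N(Cc1cnnn1-c1cccc(S(N)(=O)=O)c1)c1ccccc12` differs from compound 1 by sulfamoyl in place of methyl on an aromatic carbon. Among the compounds with values here, no measured step touches a sulfamoyl group, and no related step has a readable size, so no movement beyond the scatter is expected. For compound 4 the expected value in this assay is 60000 nM, range 20000 nM to 200000 nM, an expected step that the limit leaves unreadable from compound 1 to compound 4.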

Compound 4, half-maximal inhibitory concentration: 11300 nM
Compound 4: the middle estimate sits 5.3-fold (0.73 log units) above what was measured, outside the stated range (below it).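

Sulfamoyl on this aryl brings the number inside the measurable range of this assay, giving the first readable steps in the series: an at least 4.4-fold lower number from compound 1 to compound 4 (0.64 log units; beyond the scatter), an at least 4.4-fold lower number from compound 2 to compound 4 (0.64 log units; beyond the scatter) and an at least 4.4-fold lower number from compound 3 to compound 4 (0.64 log units; beyond the scatter). The steps among compound 1, compound 2 and compound 3 cannot be read. Each new step gives only a minimum size, because the other three compounds sit at a limit: the limit of > 50000 nM in this assay, at which 3 of the 4 values shown sit.

From the compounds shown here alone, the full size of these steps stays open. So does whether an amine or a carboxylic acid on the same aromatic carbon would also leave that limit.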